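A carbonyl added to compound 1

A few compounds are considered here, and "the series" means these few. Any claim that something is new, unique, unknown or untested is made for them only; others in the source may bear on it.

Among the measured compounds shown here, in a functional assay on SGC-7901 cells (Homo sapiens) for antiproliferative activity, read by MTT assay, with a stated time of 24 h (a lower number here means a stronger inhibitor, a higher number a weaker inhibitor), compound 1 `O=C(NNc1cccc(Cl)c1)c1ccc(NS(=O)(=O)c2cnc(O)nc2O)cc1` gives 11600 nM, the only actual number in this small set. Compound 2 `Cc1ccccc1NNC(=O)c1cccc(NS(=O)(=O)c2cnc(O)nc2O)c1` is reported only as a limit, > 20000 nM. Compound 3 `O=C(NNc1ccc(F)cc1)c1cccc(NS(=O)(=O)c2cnc(O)nc2O)c1` is likewise reported only as a limit, > 20000 nM. Compound 1 therefore stands alone beside (the limit of > 20000 nM in this assay, at which 2 of the 3 values shown sit).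

Compound 4 `O=C(NNC(=O)c1cccc(Cl)c1)c1ccc(NS(=O)(=O)c2cnc(O)nc2O)cc1` carries (3-chlorophenyl)carbonyl in place of 3-chlorophenyl on an amine nitrogen. For the measured compounds named here, the one measured step, a step that the two limits leave unreadable from compound 2 to compound 3, involves a different change and offers no size to carry over. With only compound 1 at 11600 nM as an anchor, the expected outcome in this assay is a 1.3-fold higher number from compound 1 to compound 4 (0.11 log units; within the scatter), a step no larger than the scatter and without a firm direction. For compound 4 the estimated value is 15000 nM, with an expected range of 6000 nM to 35000 nM.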

Compound 4, half-maximal inhibitory concentration: 8610 nM
For compound 4 the middle estimate is 1.7-fold (0.24 log units) above the measured one; low and high end bracket the measured number.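

In this assay, (3-chlorophenyl)carbonyl in place of 3-chlorophenyl on an amine nitrogen gives a 1.3-fold lower number from compound 1 to compound 4 (0.13 log units; within the scatter), so the added carbonyl is tolerated at this position without a change beyond the scatter. This is the first step in the set that can be read as a size, since the other two values are each a limit: the limit of > 20000 nM in this assay, at which 2 of the 4 values shown sit.

As far as these compounds go, it remains open whether an acetyl group or a longer chain carrying the 3-chlorophenyl ring on this nitrogen would move the number beyond the scatter. Also open, from the compounds shown here alone, is whether an amine in place of the chlorine would do so.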